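Replacing a five-membered ring with an open chain

The source may report more compounds than this note shows. Statements on the series, on what has been measured and on what is new or still open speak of the compounds shown alone.

Compound 1, `c1ccc(-c2cnoc2)c(NCC2=NCCN2)c1`, in a functional assay for activation of Alpha-1B adrenergic receptor (Homo sapiens), read by calcium flux (a higher number here means that more compound is needed for the effect, a lower number that less compound is needed), gives < 100000 nM, which is a limit of the assay. Compound 2, `FC(F)(F)c1cccnc1-c1ccccc1NCC1=NCCN1`, gives < 100000 nM in this assay, again a limit. Compound 3, `CO/N=C(\C)c1ccccc1NCC1=NCCN1`, gives < 5020 nM in this assay, also a limit.

Compound 1 therefore stands only on a limit, and the two other values shown are limits as well. For the measured compounds named here, the one change between measured compounds, a step that the two limits leave unreadable from compound 1 to compound 3, cannot be sized: it runs between the limit of < 100000 nM in this assay, at which 2 of the 3 values shown sit, and (the limit of < 5020 nM in this assay, at which 1 of the 3 values shown sits), and neither end is a number.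

Compound 4, `CC/C(=N\OC)c1ccccc1NCC1=NCCN1`, differs from compound 1 by a group of 6 heavy atoms (4 carbon, 1 nitrogen, 1 oxygen; no ring) in place of a group of 5 heavy atoms (3 carbon, 1 nitrogen, 1 oxygen; one five-membered aromatic ring with 2 hetero atoms), on an aromatic carbon. Going by the values given here, this change resembles the one from compound 1 to compound 3 in that a five-membered aromatic ring with 2 hetero atoms leaves and an open chain enters, here with one more carbon.

With no readable step to lean on, no size or direction is expected beyond what compound 3 suggests. Compound 4 is estimated at 3000 nM, within 300 nM to 30000 nM, which would mean an expected step that the limit leaves unreadable from compound 1 to compound 4; the estimate rests on compound 3 and its limit < 5020 nM, and a further limit rather than a number is quite possible.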

Compound 4, half-maximal effective concentration: < 100000 nM
Compound 4: a limit, no number; the forecaster's own chance of this, stated with the estimate: 50%; the middle value does not contradict the limit.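

Compound 4 gives < 100000 nM in this assay, which is a limit and not a number. For the compounds shown here, compound 1 and compound 3 also stand only on limits, so no step between these three compounds can be read. The compounds shown leave open whether replacing the 1,2-oxazol-4-yl group with an open chain changes the amount of compound needed, and by how much.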